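A few compounds are considered here, and "the series" means these few. Any claim that something is new, unique, unknown or untested is made for them only; others in the source may bear on it.

Of the compounds shown here, three that share one core have been measured in a functional assay with Alpha-1B adrenergic receptor (Homo sapiens) as the target, read by calcium flux; on this read-out lower numbers stand for smaller maximal responses and higher numbers for larger maximal responses. Compound 1 `CC(C)n1nccc1-c1ccccc1NCC1=NCCN1` gives 0% there, compound 2 `Cc1nc(-c2ccccc2NCC2=NCCN2)n(C)n1` gives 0%, and compound 3 `Cc1ccc(-c2ccccc2NCC2=NCCN2)n1C` gives 0%. Compound 2 thus stands level with compound 1 and with compound 3 at the digits shown; all three readings lie within the usual scatter of one another, so none of them can be set apart from the others on these numbers.

Compound 4 `Cc1n[nH]c(-c2ccccc2NCC2=NCCN2)n1` has not yet been measured in this assay. It differs from compound 2 in a single place: hydrogen in place of methyl on an aromatic nitrogen. Among the measured compounds shown here, no step between two measured compounds of this set involves a change of this kind, so no measured step can guide the expectation directly. Because compound 2 gives 0% and its two companions read the same at the digits shown, the change is expected to bring no step beyond the scatter, no change at the digits printed from compound 2 to compound 4 (within the scatter). Compound 4 is therefore estimated at 0% in this assay, with a range from 0% to 10%.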

Compound 4, largest response reached (reported as maximal response), in percent of the reference or control that the assay uses: 0%
For compound 4 middle estimate and measured number coincide at the digits printed; the measured number falls inside the stated range.
By their numbers in this assay, from the lowest: compounds 1, 2, 3 and 4 (each within the scatter of the next).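

In this assay, putting hydrogen in place of methyl on the aromatic nitrogen gives no change at the digits printed from compound 2 to compound 4 (within the scatter). Among the compounds shown here, this is the first measured step in the set, and it shows that the methyl on this nitrogen is not needed for the reading to stay where it is, since compound 4 gives 0%. For the compounds shown here, with both compounds at the same reading, the step shows only that this swap does not lift the maximal response, and nothing measured here explains that result.

On these data alone, it remains open whether a larger group on this same nitrogen, such as a propyl chain, a benzyl group or a chain ending in an amine, would raise the response in this assay. Also open, as far as these compounds go, is whether a carboxylic acid on the ring carbon that bears the other methyl would change the reading.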